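From a Methoxy to a Hydroxy Group: An Expected Step

This account rests on a few compounds, and the source may have more. Where it says the series, first, only, none or still open, it means among the compounds named here.

Compound 3 `COc1cc(C)cc(-c2nn(CC#N)cc2-c2ccnc(-c3ccc(N(C)C)cc3)c2)c1` stands at the low end of the three numbers reported in a functional assay on COLO 205 cells (Homo sapiens) for inhibition, read by sulforhodamine B assay, with a stated time of 48 h; on this read-out lower numbers stand for stronger inhibition of growth and higher numbers for weaker inhibition of growth: compound 3 gives 320 nM. Compound 1 `COc1cc(C)cc(-c2nn(CC#N)cc2-c2ccc(-c3cccc(C(C)=O)c3)nc2)c1` gives 1850 nM, and compound 2 `Cc1cc(O)cc(-c2nn(CC#N)cc2-c2ccnc(-c3ccc(Oc4ccccc4)cc3)c2)c1` gives 1800 nM; both values lie well beyond the scatter from that of compound 3, which therefore holds the lowest number of the set.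

Compound 4 `Cc1cc(O)cc(-c2nn(CC#N)cc2-c2ccnc(-c3ccc(N(C)C)cc3)c2)c1` differs from compound 3 in one place: hydrogen in place of methyl on an oxygen on an aromatic ring, that is, methoxy to hydroxy, or 3-methoxy-5-methylphenyl to 3-hydroxy-5-methylphenyl. Going by the values given here, no pair of measured compounds shows this change on its own, so its size cannot be read from the data. Among the compounds with values here, compound 2 carries the hydroxy group and gives 1800 nM, but it also differs from compound 3 elsewhere, so the two values show only that a hydroxy compound can sit higher. The expected step is a 1.4-fold higher number from compound 3 to compound 4 (0.15 log units; within the scatter), small and likely within the scatter. Compound 4 is estimated at 450 nM, with a range from 150 nM to 1300 nM.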

Compound 4, concentration for 50% growth inhibition: 1950 nM
Beside the measured number, compound 4's estimate is 4.3-fold (0.64 log units) below it, outside the stated range (above it).
By their numbers in this assay, from the lowest: compound 3; then compounds 2, 1 and 4 (each within the scatter of the next).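

In this assay the change from methoxy to hydroxy, now seen on its own, gives a 6.1-fold higher number from compound 3 to compound 4 (0.78 log units; beyond the scatter), so on the compounds carrying dimethylamino, the methyl on this oxygen makes a difference beyond the scatter. With the hydroxy group in place, dimethylamino in place of phenoxy gives a 1.1-fold higher number from compound 2 to compound 4 (0.03 log units; within the scatter), so the dimethylamino group alone does not bring the low number of compound 3, which among these compounds appears only with the methoxy group. The data at hand offer no explanation for this step.

As far as these compounds go, whether methoxy in place of hydroxy would give a similar step on a compound carrying phenoxy remains open. Also open, from the compounds shown here alone, is how an ethoxy group, a longer ether chain or an amine at this place on the ring would read.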